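From a Cyclohexylamino to a 4-Phenylpiperidin-1-yl Substituent

A few compounds are considered here, and "the series" means these few. Any claim that something is new, unique, unknown or untested is made for them only; others in the source may bear on it.

Of the compounds shown here, three sharing one core have been measured in a functional assay on CHO-K1 cells for antagonist activity at transient receptor potential cation channel subfamily V member 1 (Homo sapiens), read by FLIPR; on this read-out higher numbers stand for weaker inhibition and lower numbers for stronger inhibition. Compound 1 `CC(C(=O)NCc1ccc(C(F)(F)F)nc1NC1CCCCC1)c1ccc(NS(C)(=O)=O)c(F)c1` gives 260 nM in this assay, the second highest of the three numbers. Compound 2 `CC(C(=O)NCc1ccc(C(F)(F)F)nc1NCc1ccc(Cl)cc1)c1ccc(NS(C)(=O)=O)c(F)c1` gives 414 nM, and the change of a 1.6-fold higher number from compound 1 to compound 2 (0.20 log units; within the scatter) lies within the scatter. Compound 3 `CC(C(=O)NCc1ccc(C(F)(F)F)nc1N(C)c1ccccc1)c1ccc(NS(C)(=O)=O)c(F)c1` gives 57.4 nM, the lowest number of the set; the steps of a 4.5-fold lower number from compound 1 to compound 3 (0.66 log units; beyond the scatter) and a 7.2-fold lower number from compound 2 to compound 3 (0.86 log units; beyond the scatter) both go beyond the scatter.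

Compound 4 `CC(C(=O)NCc1ccc(C(F)(F)F)nc1N1CCC(c2ccccc2)CC1)c1ccc(NS(C)(=O)=O)c(F)c1` has not yet been measured. Its difference from compound 1 is 4-phenylpiperidin-1-yl in place of cyclohexylamino on an aromatic carbon. As in compound 3, the nitrogen on the aromatic carbon carries no hydrogen and the group that enters contains a six-membered aromatic ring of carbon only; unlike compound 3, the aromatic ring is held on a six-membered non-aromatic ring with 1 hetero atom. The step of a 4.5-fold lower number from compound 1 to compound 3 (0.66 log units; beyond the scatter) is the one that bears most directly on this change, while the step of a 1.6-fold higher number from compound 1 to compound 2 (0.20 log units; within the scatter) shows that adding an aromatic ring alone did not lower the number. A modest decrease in this assay is therefore expected from compound 1 to compound 4, estimated at a 2.0-fold lower number from compound 1 to compound 4 (0.30 log units; within the scatter). Compound 4 is expected to give about 130 nM in this assay, within a range of 40 nM to 450 nM.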

Compound 4, half-maximal inhibitory concentration: 25 nM
Compound 4: the middle estimate sits 5.2-fold (0.72 log units) above what was measured, and the stated range ends above it.
By their numbers in this assay, from the lowest: compound 4; then compound 3; then compounds 1 and 2 (each within the scatter of the next).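

In this assay the 4-phenylpiperidin-1-yl group gives the lowest number of the set, with a 10-fold lower number from compound 1 to compound 4 (1.02 log units; beyond the scatter) and a 17-fold lower number from compound 2 to compound 4 (1.22 log units; beyond the scatter), so this position on the shared core accepts a group of 12 heavy atoms with a large fall in the number. The group also goes past the methyl(phenyl)amino group, with a 2.3-fold lower number from compound 3 to compound 4 (0.36 log units; beyond the scatter), which shows that the earlier gain was not the limit at this aromatic carbon; among these four compounds, the two whose attached nitrogen carries no hydrogen, compound 3 and compound 4, both give lower numbers than compound 1 and compound 2, and none goes against this. No measurement shown here bears on why the number falls with this change.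

On these data alone, compound 4 changes the hydrogen on that nitrogen and the ring system in one step, so the share of each in the fall stays open. A plain piperidin-1-yl group would show what the phenyl ring contributes, and a 4-(4-chlorophenyl)piperidin-1-yl or 4-benzylpiperidin-1-yl group would show whether the number moves further when that ring is substituted or set one carbon away.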